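Thiophene in Place of Benzofuran on a Nucleoside Core

The source may hold more compounds than are shown below. What is called first, only, known or untested is meant among the compounds shown, and "the series" means these compounds.

The measured compounds:
compound 1, `Cc1ncnc2c1c(-c1cc3ccccc3o1)cn2[C@@H]1O[C@H](CO)[C@@H](O)[C@H]1O`;
compound 2, `Cc1nc(N)c2c(-c3cc4ccccc4o3)cn([C@@H]3O[C@H](CO)[C@@H](O)[C@H]3O)c2n1`;
compound 3, `Cc1ncnc2c1c(-c1ccsc1)cn2[C@@H]1O[C@H](CO)[C@@H](O)[C@H]1O`.

In a functional assay on K562 cells (Homo sapiens), read by MTT assay, with a stated time of 72 h (on this read-out higher numbers stand for weaker inhibition and lower numbers for stronger inhibition), compound 1 gives only a limit, > 20000 nM, and not a number. Compound 2 gives 4990 nM in this assay, and compound 3 gives 5550 nM. The values of compound 2 and compound 3 lie within the usual scatter of each other. The change thiophen-3-yl in place of 1-benzofuran-2-yl on an aromatic carbon made the step of an at least 3.6-fold lower number from compound 1 to compound 3 (0.55 log units; beyond the scatter), and since compound 1 sits at a limit (the limit of > 20000 nM in this assay, at which 1 of the 3 values shown sits), the true step may be larger than that. How the core of compound 1 and the core of compound 2 differ is not broken down here.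

Compound 4, `Cc1nc(N)c2c(-c3ccsc3)cn([C@@H]3O[C@H](CO)[C@@H](O)[C@H]3O)c2n1`, has not yet been measured in this assay. It differs from compound 2 by thiophen-3-yl in place of 1-benzofuran-2-yl on an aromatic carbon, the same change as from compound 1 to compound 3, at the same place. Compound 4 is therefore expected to show a step of a 3.3-fold lower number from compound 2 to compound 4 (0.52 log units; beyond the scatter), resting on the step of an at least 3.6-fold lower number from compound 1 to compound 3 (0.55 log units; beyond the scatter) and on the value of compound 2, 4990 nM. Compound 4 is estimated at 1500 nM, likely between 400 nM and 5000 nM.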

Compound 4, half-maximal inhibitory concentration: > 20000 nM
Compound 4 ended at the assay's limit; the forecaster's own chance of this, stated with the estimate: 5%; middle value at least 13-fold (1.12 log units) from the limit.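

On the core of compound 2, thiophen-3-yl in place of 1-benzofuran-2-yl gave an at least 4.0-fold higher number from compound 2 to compound 4 (0.60 log units; beyond the scatter), so in this assay the change did not carry over from the core of compound 1 to this core: the same change on two cores in this assay, an at least 3.6-fold lower number (0.55 log units; beyond the scatter) from compound 1 to compound 3 and an at least 4.0-fold higher number (0.60 log units; beyond the scatter) from compound 2 to compound 4, at least 14-fold (1.15 log units) apart, beyond the scatter of two such steps

Compound 4 gives > 20000 nM, which is a limit of the assay and not a number.

Both steps therefore have only a minimum size, and these two pairs do not show why the direction differs or how the change would behave on any further core: the limit of > 20000 nM in this assay, at which 2 of the 4 values shown sit.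

The compounds shown carry only these two groups at this place. From the compounds shown here alone, how a phenyl or a furan-2-yl group there would read on either core remains open.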